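Ring-nitrogen substituent series: three measured, one pending

The compounds below may be only part of what the source reports. "The series", "measured", "known", "first", "only" and "open" are said of these compounds alone.

Measured so far, in an assay on isolated protein for inhibition of Gonadotropin-releasing hormone receptor (Homo sapiens); a higher number here means a weaker inhibitor, a lower number a stronger inhibitor:
- compound 1 `CCn1c(SCc2cc([N+](=O)[O-])ccc2OC)nc2cc(NC(=O)NC(C)(C)C)ccc21` gives 42 nM
- compound 2 `COc1ccc([N+](=O)[O-])cc1CSc1nc2cc(NC(=O)NC(C)(C)C)ccc2n1Cc1cccnc1` gives 33 nM
- compound 3 `COc1ccc([N+](=O)[O-])cc1CSc1nc2cc(NC(=O)NC(C)(C)C)ccc2n1Cc1ccncc1` gives 47 nM

Compound 3 holds the highest of the three numbers in this assay, but its distance to compound 1 and to compound 2 is small: a 1.1-fold higher number from compound 1 to compound 3 (0.05 log units; within the scatter) and a 1.4-fold higher number from compound 2 to compound 3 (0.15 log units; within the scatter) both stay within the scatter, as does a 1.3-fold lower number from compound 1 to compound 2 (0.10 log units; within the scatter). No ordering among the three is therefore supported.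

Compound 4 `COc1ccc([N+](=O)[O-])cc1CSc1nc2cc(NC(=O)NC(C)(C)C)ccc2n1-c1ccccc1` is not yet measured. It differs from compound 3 in one place: phenyl in place of (pyridin-4-yl)methyl on an aromatic nitrogen. The measured steps all exchange the group on the saturated chain carbon bound to the aromatic nitrogen, with ethyl, (pyridin-3-yl)methyl and (pyridin-4-yl)methyl giving indistinguishable numbers. None of them removes that chain carbon or places an aromatic ring directly on the ring nitrogen, so the present step is only partly covered. Given that every covered exchange at this position left the number unchanged, no shift beyond the scatter is expected, and the estimated step is a 1.1-fold higher number from compound 3 to compound 4 (0.03 log units; within the scatter). Compound 4 is thus estimated at 50 nM in this assay, with a range from 18 nM to 160 nM that is widened because the change is not directly precedented.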

Compound 4, half-maximal inhibitory concentration: 350 nM
Compound 4: the middle estimate sits 7.0-fold (0.85 log units) below what was measured; the measured number lies above the stated range.
By their numbers in this assay, from the lowest: compounds 2, 1 and 3 (each within the scatter of the next); then compound 4.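

In this assay, the position proves sensitive once the group on the aromatic nitrogen changes in kind: phenyl gives a 7.4-fold higher number from compound 3 to compound 4 (0.87 log units; beyond the scatter), an 11-fold higher number from compound 2 to compound 4 (1.03 log units; beyond the scatter) and an 8.3-fold higher number from compound 1 to compound 4 (0.92 log units; beyond the scatter), all beyond the scatter, although ethyl, (pyridin-3-yl)methyl and (pyridin-4-yl)methyl could not be told apart. Those three groups share a saturated chain carbon on the aromatic nitrogen, which phenyl lacks, so carrying an aromatic ring is not enough on its own to keep the number low, as compound 4 shows. Nothing available explains the rise.

Compound 4 differs from compounds 2 and 3 both in losing the chain carbon and in having no ring nitrogen, and a benzyl group or a directly attached pyridin-4-yl would separate those two changes. Going by these compounds, how a longer chain, such as 2-phenylethyl, behaves here also remains open.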